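The compounds below may be only part of what the source reports. "The series", "measured", "known", "first", "only" and "open" are said of these compounds alone.

Measured compounds in an assay on Sf9 cells for inhibition of protein deacetylase HDAC6 (Homo sapiens), read by fluorescence, with a stated time of 40 min, tested at 100 nM; a higher number here means more inhibition at the concentration tested (going by the name of the read-out), a lower number less inhibition:
- compound 1 `Cc1ccccc1-c1nc(CNc2ccc(C(=O)NO)cc2)n(-c2ccccc2)n1` gives 53.2%
- compound 2 `O=C(NO)c1ccc(NCc2nc(-c3ccccc3Cl)nn2-c2ccccc2)cc1` gives 75%
- compound 3 `O=C(NO)c1ccc(NCc2nc(-c3ccc(Br)o3)nn2-c2ccccc2)cc1` gives 55.8%

Compound 3 stands second highest of the three numbers in this assay; its nearest neighbour is compound 1, a gap that lies within the scatter, and its furthest is compound 2, which sits beyond the scatter above it.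

Compound 4 `CCc1ccc(-c2nc(CNc3ccc(C(=O)NO)cc3)n(-c3ccccc3)n2)cc1` is not yet measured. Its difference from compound 3 is 4-ethylphenyl in place of 5-bromofuran-2-yl on an aromatic carbon.

For the measured compounds named here, two measured steps bear on this change, both being an exchange of the group on the same aromatic carbon between two ring nitrogen atoms. The step of a number 2.6 percentage points higher from compound 1 to compound 3 (within the scatter) shows that exchanging 2-methylphenyl for 5-bromofuran-2-yl moved the number within the scatter. The step of a number 19.2 percentage points lower from compound 2 to compound 3 (beyond the scatter) shows a modest fall when 2-chlorophenyl gave way to 5-bromofuran-2-yl. Going back from 5-bromofuran-2-yl to a phenyl ring, now 4-ethylphenyl, is therefore expected to give at most a small rise, a number 2.2 percentage points higher from compound 3 to compound 4 (within the scatter), within or only just beyond the scatter; no measured compound carries 4-ethylphenyl, so the direction is uncertain. Compound 4 is estimated at 58%, with a range of 40% to 76%.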

Compound 4, a percentage reported as inhibition, at one concentration (the size of the read-out at that concentration, not a potency): 54.6%
Beside the measured number, compound 4's estimate is 3.4 percentage points above it; low and high end bracket the measured number.
By their numbers in this assay, from the lowest: compounds 1, 4 and 3 (each within the scatter of the next); then compound 2.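

In this assay the step of a number 1.2 percentage points lower from compound 3 to compound 4 (within the scatter) and the step of a number 1.4 percentage points higher from compound 1 to compound 4 (within the scatter) show that 4-ethylphenyl, with 8 heavy atoms, all carbon, reads level with both 5-bromofuran-2-yl and 2-methylphenyl on this aromatic carbon between two ring nitrogen atoms. For the compounds shown here, the step of a number 20.4 percentage points lower from compound 2 to compound 4 (beyond the scatter) leaves 2-chlorophenyl as the only group of the four that stands apart, now against three others rather than two. Nothing measured here accounts for that separation.

Going by these compounds, whether the separation belongs to the chloro group itself stays open, since 4-ethylphenyl and 2-chlorophenyl differ as whole groups. A phenyl ring carrying an amine or a carboxylic acid on this carbon is also untested among the compounds shown, so the range of groups that read level remains unknown.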